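A few compounds are considered here, and "the series" means these few. Any claim that something is new, unique, unknown or untested is made for them only; others in the source may bear on it.

Measured so far in an in vitro ADME assay on microsomes from liver (Homo sapiens) for metabolic stability, in the presence of a further agent that is not named here; on this read-out lower numbers stand for slow clearance and higher numbers for fast clearance

compound 1 `CC(C)(CO)CNC(=O)c1cc2cc(C#N)ccc2n1Cc1cccc(OC(F)(F)F)c1` gives 20 mL.min-1.g-1
compound 2 `COc1ccc(OC(F)(F)F)cc1Cn1c(C(=O)NCC(C)(C)CO)cc2cc(C#N)ccc21` gives 31 mL.min-1.g-1
compound 3 `CC(C)(CO)CNC(=O)c1cc2cc(C#N)ccc2n1Cc1cc(Cl)cc(Cl)c1` gives 22 mL.min-1.g-1

Compound 3 (at 22 mL.min-1.g-1) lies within the scatter of both other compounds, so the three cannot be ranked. Compound 4 `COc1ccc(Cl)cc1Cn1c(C(=O)NCC(C)(C)CO)cc2cc(C#N)ccc21` carries 5-chloro-2-methoxyphenyl in place of 3,5-dichlorophenyl on a saturated chain carbon bound to an aromatic nitrogen. Among the measured compounds shown here, one measured step bears on this change. It also adds a methoxy group, and it reads a 1.6-fold higher number from compound 1 to compound 2 (0.19 log units; within the scatter) in this series. For the measured compounds named here, no measured step covers the loss of a chlorine. A small rise is therefore expected, and the estimated step is a 1.3-fold higher number from compound 3 to compound 4 (0.10 log units; within the scatter) and stays within the scatter. Compound 4 is expected to give 28 mL.min-1.g-1 (estimated range 14 mL.min-1.g-1 to 55 mL.min-1.g-1).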

Compound 4, intrinsic clearance in microsomes: 10 mL.min-1.g-1
Compound 4: the middle estimate sits 2.8-fold (0.45 log units) above what was measured, and the stated range ends above it.
By their numbers in this assay, from the lowest: compounds 4, 1, 3 and 2 (each within the scatter of the next, the first and the last beyond it).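

In this assay, among the compounds shown here, this position on a saturated chain carbon bound to an aromatic nitrogen now shows a clear effect: 5-chloro-2-methoxyphenyl in place of 3,5-dichlorophenyl gives a 2.2-fold lower number from compound 3 to compound 4 (0.34 log units; beyond the scatter) and is the first change here to pass the scatter, alongside the next one. Chloro in place of trifluoromethoxy on an aromatic carbon gives a 3.1-fold lower number from compound 2 to compound 4 (0.49 log units; beyond the scatter) with the methoxy group kept. Nothing measured here explains either step. From the compounds shown here alone, whether fluoro or an amine in place of that chloro would keep the lower number remains open.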